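Piperazine for pyrrolidine at the benzylic amine of compound 2

A few compounds are considered here, and "the series" means these few. Any claim that something is new, unique, unknown or untested is made for them only; others in the source may bear on it.

In a functional assay on A549 cells (Homo sapiens) for cytotoxicity, read by MTT assay, with a stated time of 72 h (on this read-out lower numbers stand for stronger inhibition and higher numbers for weaker inhibition), compound 1 `CNCCN(C)Cc1ccc(-c2ccnc3ccc(-c4cnc(OC)c(NS(=O)(=O)c5ccc(F)cc5F)c4)cc23)cc1` gives 13 nM, and compound 2 `COc1ncc(-c2ccc3nccc(-c4ccc(CN5CCCC5)cc4)c3c2)cc1NS(=O)(=O)c1ccc(F)cc1F` gives 37.5 nM, the higher of the two numbers, after a step of a 2.9-fold higher number from compound 1 to compound 2 (0.46 log units; beyond the scatter). Compound 3 `COc1ncc(-c2ccc3nccc(-c4ccc(CN5CCN(C)CC5)cc4)c3c2)cc1NS(=O)(=O)c1ccc(F)cc1F` carries 4-methylpiperazin-1-yl in place of pyrrolidin-1-yl on a saturated chain carbon bound to an aromatic carbon. Within the data shown here, the only step seen, from compound 1 to compound 2, concerns the same position and was modest, so a change of similar or smaller size is expected here, with the direction open. Compound 3 is therefore expected at 25 nM, between 10 nM and 70 nM, a step of a 1.5-fold lower number from compound 2 to compound 3 (0.18 log units; within the scatter).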

Compound 3, half-maximal inhibitory concentration: 13.3 nM
Beside the measured number, compound 3's estimate is 1.9-fold (0.27 log units) above it; the measured number falls inside the stated range.
By their numbers in this assay, from the lowest: compounds 1 and 3 (each within the scatter of the next); then compound 2.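

At this position, on a saturated chain carbon bound to an aromatic carbon, in this assay, replacing pyrrolidin-1-yl with 4-methylpiperazin-1-yl gives a 2.8-fold lower number from compound 2 to compound 3 (0.45 log units; beyond the scatter), so the change of amine moves the number in the opposite direction to the earlier step. The 4-methylpiperazin-1-yl ring and the open methyl(2-(methylamino)ethyl)amino chain cannot be told apart, with a 1.0-fold higher number from compound 1 to compound 3 (0.01 log units; within the scatter), which leaves pyrrolidin-1-yl alone with the higher number. No evidence here explains these steps. The compounds shown leave open whether morpholin-4-yl, or piperazin-1-yl without its methyl group, would match compound 3 or compound 2.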